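Replacing the isopropylpiperazine of compound 1 with a methyl-oxopiperazine

A few compounds are considered here, and "the series" means these few. Any claim that something is new, unique, unknown or untested is made for them only; others in the source may bear on it.

This account follows compound 1 `CC(C)N1CCN(c2ccc3c(c2)oc(=O)n3C(=O)NCCCCc2ccccc2)CC1`, which in an assay on HEK293 cells for inhibition of acid ceramidase (Homo sapiens), read by fluorescence, with stated times of 10 min and 3 h (a lower number here means a stronger inhibitor, a higher number a weaker inhibitor), gives 211 nM. Among the three measured compounds it has the second-highest number: compound 2 `CN1CCc2oc(=O)n(C(=O)NCCCCc3ccccc3)c2C1` gives 516 nM, and compound 3 `CCCCCNC(=O)n1c(=O)oc2cc(-c3ccc(F)cc3)ccc21` gives 60 nM. Compound 4 `CN1CCN(c2ccc3c(c2)oc(=O)n3C(=O)NCCCCc2ccccc2)CC1=O` has not been measured. It differs from compound 1 in one place: 4-methyl-3-oxopiperazin-1-yl in place of 4-isopropylpiperazin-1-yl on an aromatic carbon. Among the compounds with values here, no step between two measured compounds isolates this change, so the expectation rests on compound 1 alone. The author expects compound 4 to give 320 nM, with a range from 120 nM to 850 nM. The step from compound 1 to compound 4 is thus estimated as a 1.5-fold higher number from compound 1 to compound 4 (0.18 log units; within the scatter), a modest weakening that may well fall within the scatter.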

Compound 4, half-maximal inhibitory concentration: 92 nM
The estimate for compound 4 lay 3.5-fold (0.54 log units) above the measured number; measured number outside the range, below it.
By their numbers in this assay, from the lowest: compounds 3 and 4 (each within the scatter of the next); then compound 1; then compound 2.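

In this assay, the change on this aromatic carbon gives a 2.3-fold lower number from compound 1 to compound 4 (0.36 log units; beyond the scatter), so an isopropyl-bearing piperazine is not required here and 4-methyl-3-oxopiperazin-1-yl is tolerated. Within the data shown here, this is the first step that isolates a single change at this position, which the earlier compounds, differing in several places, could not do. Nothing measured here explains the step. Going by these compounds, the change adds a ring carbonyl and replaces isopropyl with methyl together, so which of the two carries the step remains open. On these data alone, whether morpholine at this carbon would behave alike also remains open.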